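A Mirror-Image Change at the Chain Carbon

This account rests on a few compounds, and the source may have more. Where it says the series, first, only, none or still open, it means among the compounds named here.

Compound 1 `O=C(O)[C@H](CO)NC(=O)[C@H]1C[C@H](O)CN1` was run in a physicochemical assay for metabolic stability, read by HPLC, in phosphate buffer, with a stated time of 12 h, at pH 6.8; on this read-out higher numbers stand for a longer-lived compound and lower numbers for a shorter-lived compound. In this assay compound 1 reaches > 12 h, which is a limit of the assay rather than a number. Compound 2 `O=C(O)[C@H](CO)NC(=O)[C@@H]1C[C@H](O)CN1` shares every atom and bond with compound 1 and differs only at one ring stereocentre. In this assay compound 2 also gives > 12 h, again a limit. The step that the two limits leave unreadable from compound 1 to compound 2 cannot be sized, since both readings rest at the limit of > 12 h in this assay, at which 2 of the 2 values shown sit, even though the pair rests on (the fact that compounds 1 and 2 differ only in the configuration as drawn).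

Compound 3 `O=C(O)[C@@H](CO)NC(=O)[C@H]1C[C@H](O)CN1` differs from compound 1 by the two compounds have the same atoms and bonds and differ only in configuration as drawn: 1 of 3 stereo elements differ; a stereocentre at a saturated chain carbon is drawn S in compound 1 and R in compound 3. Going by the values given here, the single measured step offers no readable size, so nothing beyond the scatter can be foreseen; with both known values at the limit, the expected step, a step that the limit leaves unreadable from compound 1 to compound 3, is none beyond the scatter. Compound 3 is therefore estimated at 20 h, within 10 h to 48 h, most likely reported as a limit once more.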

Compound 3, half-life: > 12 h
Compound 3: no number, only a limit; the forecaster's own chance of this, stated with the estimate: 80%; the middle value lies beyond the limit too.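

In this assay, going by these compounds alone, compound 3 gives > 12 h, a limit and not a number, and no step linking it to compound 1 or compound 2 can be read. The compounds shown leave open how long each one actually lasts, and whether changing either stereocentre alters the half-life at all.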